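Swapping the Dimethoxyphenyl for a Methylphenyl

A few compounds are considered here, and "the series" means these few. Any claim that something is new, unique, unknown or untested is made for them only; others in the source may bear on it.

Three measured compounds share one core and differ only in the aromatic group attached to it. Compound 1 `COc1cc(C(=O)c2sc(-c3ccc(Br)cc3)cc2N)cc(OC)c1OC` carries a 4-bromophenyl; in a functional assay on CCRF-CEM cells (Homo sapiens) for antiproliferative activity (on this read-out higher numbers stand for weaker inhibition and lower numbers for stronger inhibition), compound 1 gives 86 nM. Compound 2 `COc1ccc(-c2cc(N)c(C(=O)c3cc(OC)c(OC)c(OC)c3)s2)cc1OC` carries a 3,4-dimethoxyphenyl, and in this assay compound 2 gives 20 nM, the lowest number and so the strongest inhibition of the three. Compound 3 `COc1cc(C(=O)c2sc(-c3ccc([N+](=O)[O-])cc3)cc2N)cc(OC)c1OC` carries a 4-nitrophenyl; in this assay compound 3 gives 99 nM. The steps show a 4.3-fold lower number from compound 1 to compound 2 (0.63 log units; beyond the scatter) and a 5.0-fold higher number from compound 2 to compound 3 (0.69 log units; beyond the scatter), whereas a 1.2-fold higher number from compound 1 to compound 3 (0.06 log units; within the scatter). The 3,4-dimethoxyphenyl thus stands apart, while the 4-bromophenyl and 4-nitrophenyl compounds sit close together.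

Compound 4 `COc1cc(C(=O)c2sc(-c3ccc(C)cc3)cc2N)cc(OC)c1OC` has not yet been measured. It differs from compound 2 as follows: 4-methylphenyl in place of 3,4-dimethoxyphenyl on an aromatic carbon. The two steps that remove the 3,4-dimethoxyphenyl both bear on this change, and both raised the number modestly. A modest rise beyond the scatter is therefore expected, a 3.8-fold higher number from compound 2 to compound 4 (0.57 log units; beyond the scatter). Compound 4 is estimated to give 75 nM, with a likely range from 30 nM to 190 nM.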

Compound 4, half-maximal inhibitory concentration: 15 nM
The estimate for compound 4 lay 5.0-fold (0.70 log units) above the measured number; measured number outside the range, below it.
By their numbers in this assay, from the lowest: compounds 4 and 2 (each within the scatter of the next); then compounds 1 and 3 (each within the scatter of the next).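

Within the data shown here, the step of a 1.3-fold lower number from compound 2 to compound 4 (0.12 log units; within the scatter) shows, in this assay, that the 3,4-dimethoxyphenyl is not the only group at this position, next to the ring sulfur, that goes with a low number: the 4-methylphenyl, with fewer heavy atoms and no hydrogen-bond acceptors, does as well within the scatter. Among these compounds, the group carried on the phenyl ring also matters more than the earlier compounds could show, since exchanging only that group gives a 6.6-fold lower number from compound 3 to compound 4 (0.82 log units; beyond the scatter) and a 5.7-fold lower number from compound 1 to compound 4 (0.76 log units; beyond the scatter). No measurement shown here explains why methyl and the two methoxy groups stand together, apart from bromo and nitro.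

As far as these compounds go, whether an ethyl, a methoxy or an amino group in place of the methyl would keep the number as low remains open. So does whether a longer chain at that spot would do the same.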